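The source may hold more compounds than are shown below. What is called first, only, known or untested is meant among the compounds shown, and "the series" means these compounds.

Of the compounds shown here, two built on the same core have been measured in an assay on isolated protein (strain Sprague-Dawley) for inhibition of Amine oxidase [flavin-containing] A (Rattus norvegicus), read by spectrophotometry, with a stated time of 5 min, tested at 10 uM; on this read-out higher numbers stand for more inhibition at the one concentration tested (going by the name of the read-out) and lower numbers for less inhibition. Compound 1 `O=C(COc1cc(=O)oc2cc(OCc3cccc(Cl)c3)ccc12)N1CCCCC1` gives 9%, and compound 2 `CCNC(=O)Nc1cc(=O)oc2cc(OCc3cccc(Cl)c3)ccc12` gives 0%. Going by the values given here, the one step between them, a number 9 percentage points lower from compound 1 to compound 2 (within the scatter), falls within the scatter, so the two numbers cannot be ordered. On the numbers shown, compound 2 holds the lowest value of the two, with compound 1 as its nearest neighbour at a distance that the scatter covers.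

Compound 3 `N#Cc1cc(=O)oc2cc(OCc3cccc(Cl)c3)ccc12` has not yet been measured. It differs from compound 2 in one place: cyano in place of (ethylcarbamoyl)amino on an aromatic carbon. Among the compounds with values here, no measured step touches this change; the only step available, from compound 1 to compound 2, replaced a different group and moved the read-out by an amount within the scatter. Both measured compounds sit at the low end of the scale in this assay, so nothing here points to a move beyond the scatter in either direction.

The expected step is a number 10 percentage points higher from compound 2 to compound 3 (within the scatter). Compound 3 is therefore estimated at 10%, with a range from 0% to 35%.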

Compound 3, a percentage reported as inhibition, at one concentration (the size of the read-out at that concentration, not a potency): 23%
Estimate against measurement, compound 3: 13 percentage points below; measured number inside the range.
By their numbers in this assay, from the lowest: compounds 2 and 1 (each within the scatter of the next); then compound 3.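

In this assay, this position, on an aromatic carbon opposite the ring oxygen, now gives a change that can be read: replacing (ethylcarbamoyl)amino with cyano gives a number 23 percentage points higher from compound 2 to compound 3 (beyond the scatter), and replacing ((piperidin-1-yl)carbonyl)methoxy with cyano gives a number 14 percentage points higher from compound 1 to compound 3 (beyond the scatter). Going by these compounds alone, the earlier pair could not be ordered, so the group on this carbon had not yet been seen to shift the read-out, whereas cyano stands apart from both earlier groups. In the step from compound 2, the cyano group has fewer heavy atoms and no hydrogen-bond donors, but these differences change together, and nothing shown accounts for the rise.

Compound 3 reaches only 23% at the one concentration tested, so the result marks a modest rise and gives no potency. The compounds shown leave open whether the rise is particular to cyano or would also appear with a carboxylic acid, an amine or a methyl group on this carbon, and whether it would persist with a different group in place of the rest of the shared core.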